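A few compounds are considered here, and "the series" means these few. Any claim that something is new, unique, unknown or untested is made for them only; others in the source may bear on it.

Measured so far:
Compound 1 `O=C(N[C@H](/C=C/S(=O)(=O)c1ccccc1)CCc1ccccc1)c1cccc2cccnc12`: > 80000 nM
Compound 2 `CCC[C@@H](/C=C/S(=O)(=O)c1ccccc1)NC(=O)c1cccc2cccnc12`: > 80000 nM
Compound 3 `O=C(NC/C=C/S(=O)(=O)c1ccccc1)c1cccc2cccnc12`: 55500 nM

In an ADME assay on HepG2 cells (Homo sapiens) for cytotoxicity (on this read-out lower numbers stand for higher toxicity in this test and higher numbers for lower toxicity in this test), compound 1 gives > 80000 nM, which is a limit and not a number. Compound 2 gives > 80000 nM, and this too is a limit. Compound 1 therefore stands at the limit of > 80000 nM in this assay, at which 2 of the 3 values shown sit. Only compound 3 has a true number, 55500 nM.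

Compound 4 `Cn1cc([N+](=O)[O-])nc1C(=O)N[C@H](/C=C/S(=O)(=O)c1ccccc1)CCc1ccccc1` keeps the chain of compound 1 and changes the group on the carbonyl carbon: 1-methyl-4-nitro-1H-imidazol-2-yl in place of quinolin-8-yl on a carbonyl carbon. The measured steps all alter the chain instead. They are a step that the two limits leave unreadable from compound 1 to compound 2, an at least 1.4-fold lower number from compound 1 to compound 3 (0.15 log units; that floor lies within the scatter) and an at least 1.4-fold lower number from compound 2 to compound 3 (0.15 log units; that floor lies within the scatter). None of them touches the group that changes here, so they bear on this exchange only indirectly, by showing how little the read-out has moved so far.

The expectation therefore rests on the general level of the series, with compound 3 at 55500 nM. No step beyond the scatter is expected in this assay, and another limit is about as likely as a number. For compound 4 the estimated value is 70000 nM, with an expected range from 30000 nM to 120000 nM. This estimate means an expected at least 1.1-fold lower number from compound 1 to compound 4 (0.05 log units; that floor lies within the scatter).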

Compound 4, half-maximal cytotoxic concentration: 28800 nM
The estimate for compound 4 lay 2.4-fold (0.39 log units) above the measured number; the measured number lies below the stated range.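

Going by these compounds alone, until now every readable step altered the chain, so the group on the carbonyl carbon is varied here for the first time, and in this assay exchanging quinolin-8-yl for 1-methyl-4-nitro-1H-imidazol-2-yl gives an at least 2.7-fold lower number from compound 1 to compound 4 (0.44 log units; beyond the scatter). Within the data shown here, this is the first step printed as beyond the scatter, and it shows that, with the chain of compound 1 kept, the read-out responds to this group by moving towards higher toxicity in this test. The step is a floor and not a full size, since compound 1 carries only a limit: the limit of > 80000 nM in this assay, at which 2 of the 4 values shown sit.

With a single exchange on the carbonyl carbon, the compounds shown cannot tell whether the step belongs to the nitro group, the methyl group or the five-membered ring itself, nor whether it would recur on the shorter chains of compound 2 or compound 3. A 1-methyl-1H-imidazol-2-yl group without the nitro group, or the same ring carrying an amine in its place, would help to separate these possibilities.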